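The compounds below may be only part of what the source reports. "The series", "measured", "known", "first", "only" and "open" are said of these compounds alone.

Three compounds of this series carry a value in a functional assay on M12 cells (Homo sapiens) for antiproliferative activity, read by WST assay, with a stated time of 72 h; a higher number here means that more compound is needed for the effect, a lower number that less compound is needed. Compound 1, `CCCCCCCC/C=C\c1c(C)cc(C)nc1CCCOC`, gives 31.7 uM. Compound 2, `CCCCCCCC/C=C\c1c(C)c(/C=C/CCCCCCCC)c2[n+](c1C)CCC2`, gives 2.2 uM. Compound 3, `CCCCCCCCCCc1c(C)c(CCCCCCCCCC)c2[n+](c1C)CCC2`, gives 1.9 uM. Compound 2 thus holds the second highest of the three numbers; its nearest neighbour is compound 3, whose number lies within the scatter of it, while compound 1 stands furthest away with a number beyond the scatter above it.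

Compound 4, `CCCCCCCC/C=C\c1c(C)c(/C=C/CCCCCCCC)c(C)[n+]2c1CCC2`, has not yet been measured in this assay. Against compound 2 it shows (the two compounds have the same atoms and bonds and differ only in configuration as drawn: 2 of 2 stereo elements differ; a double bond is drawn E in compound 2 and Z in compound 4; a double bond is drawn Z in compound 2 and E in compound 4). Among the measured compounds shown here, no step between two measured compounds matches this change, so the expectation rests on the closeness of compound 2 and compound 3 in this assay, which suggests that the configuration of the side chains carries little weight here. A step no larger than the scatter, in either direction, is expected from compound 2 to compound 4, namely a 1.0-fold higher number from compound 2 to compound 4 (0.02 log units; within the scatter). Compound 4 is therefore estimated at 2.3 uM in this assay, with a range from 1.1 uM to 5 uM.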

Compound 4, concentration for half-maximal effect: 2.4 uM
For compound 4 the middle estimate is 1.0-fold (0.02 log units) below the measured one; measured number inside the range.
By their numbers in this assay, from the lowest: compounds 3, 2 and 4 (each within the scatter of the next); then compound 1.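

In this assay, exchanging the drawn configurations of the two double bonds gives a 1.1-fold higher number from compound 2 to compound 4 (0.04 log units; within the scatter), and this step lies within the scatter. Before this result no step between measured compounds existed, so this is the first pair in the series that isolates a single kind of change, with nothing leaving and nothing entering. In this one pair, the exchange of configuration at both double bonds together leaves the numbers indistinguishable, and the comparison rests on one fact: the fact that compounds 2 and 4 differ only in the configuration as drawn

As far as these compounds go, both double bonds differ together in this pair, and what each contributes on its own stays open. Also open, from the compounds shown here alone, is how this assay would read for side chains carrying an amine or a carboxylic acid, or for a longer chain.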